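Shifting a Methoxy Group on the Aryl Ring in Mice

The source may hold more compounds than are shown below. What is called first, only, known or untested is meant among the compounds shown, and "the series" means these compounds.

Compound 1 `COc1cc(OC)c(OC)cc1/C=C/COC(=O)/C=C/c1ccc(Br)cc1` gives 75% in a functional assay on the whole organism (strain Kunming) with Mus musculus as the target, with a stated time of 0.5 h, at a dose of 300 mg/kg by the intraperitoneal route; a lower number here means a stronger effect, a higher number a weaker effect of the compound at the dose given. Compound 2 `COc1cccc(/C=C/C(=O)OC/C=C/c2cc(OC)c(OC)cc2OC)c1` gives 75% in this assay, so the two stand level, and the step of no change at the digits printed from compound 1 to compound 2 (within the scatter) shows that exchanging the aryl group on the double-bonded chain carbon left the read-out unchanged within the scatter. Going by the values given here, compound 2 therefore sits at the same level as its only measured neighbour, compound 1.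

Compound 3 `COc1ccc(/C=C/C(=O)OC/C=C/c2cc(OC)c(OC)cc2OC)cc1` differs from compound 2 in one way: 4-methoxyphenyl in place of 3-methoxyphenyl on a double-bonded chain carbon bound to a double-bonded chain carbon. Among the compounds with values here, the single measured step that bears on this place, from compound 1 to compound 2, was within the scatter, and it is the only guide available. On that basis the expected step of no change at the digits printed from compound 2 to compound 3 (within the scatter) is none beyond the scatter. Compound 3 is therefore estimated to give 75% in this assay, with a range from 60% to 90%.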

Compound 3, a percentage reported as activity, at one dose (the size of the read-out at that dose, not a potency): 100%
Compound 3: middle estimate off by 25 percentage points, on the low side; the measured number lies above the stated range.
By their numbers in this assay, from the lowest: compounds 1 and 2 (each within the scatter of the next); then compound 3.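

In this assay a higher number means a weaker effect, and the aryl group on the double-bonded chain carbon proves not to be indifferent: 4-methoxyphenyl in place of 3-methoxyphenyl gives a number 25 percentage points higher from compound 2 to compound 3 (beyond the scatter) even though the two groups hold the same atoms. Methoxy in place of bromo on an aromatic carbon gives a number 25 percentage points higher from compound 1 to compound 3 (beyond the scatter) and thus sets the 4-methoxyphenyl group apart from the 4-bromophenyl group as well, although the 3-methoxyphenyl and 4-bromophenyl groups could not be told apart in the earlier step. No measurement here explains why these groups differ.

As far as these compounds go, it remains open whether the weaker effect is specific to the 4-methoxyphenyl group. A 4-aminophenyl or 4-carboxyphenyl group in the same place could read like compound 3 or like compound 2.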